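Triazole aryl series: chloro position on the phenyl ring

The compounds below may be only part of what the source reports. "The series", "measured", "known", "first", "only" and "open" are said of these compounds alone.

Measured in a functional assay on SGC-7901 cells (Homo sapiens) for antiproliferative activity, read by MTT assay, with a stated time of 24 h; a higher number here means a weaker inhibitor, a lower number a stronger inhibitor:
compound 1 `O=c1[nH]cc(S(=O)(=O)Nc2cccc(-c3cn(-c4ccccc4)nn3)c2)c(=O)[nH]1` gives 17200 nM
compound 2 `O=c1[nH]cc(S(=O)(=O)Nc2cccc(-c3cn(-c4cccc(F)c4)nn3)c2)c(=O)[nH]1` gives > 20000 nM, a limit of the assay
compound 3 `O=c1[nH]cc(S(=O)(=O)Nc2cccc(-c3cn(-c4ccccc4Cl)nn3)c2)c(=O)[nH]1` gives 3010 nM

Compound 3 holds the lowest number of the two actual values; compound 1 sits a 5.7-fold lower number from compound 1 to compound 3 (0.76 log units; beyond the scatter) away from it, and compound 2 rests at the limit of > 20000 nM in this assay, at which 1 of the 3 values shown sits. Going by the values given here, the steps so far concern the phenyl on the triazole nitrogen: an at least 1.1-fold higher number from compound 1 to compound 2 (0.06 log units; that floor lies within the scatter), whereas a 5.7-fold lower number from compound 1 to compound 3 (0.76 log units; beyond the scatter), and an at least 6.6-fold lower number from compound 2 to compound 3 (0.82 log units; beyond the scatter).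

Compound 4 `O=c1[nH]cc(S(=O)(=O)Nc2cccc(-c3cn(-c4ccc(Cl)cc4)nn3)c2)c(=O)[nH]1` has not been measured. It differs from compound 3 by 4-chlorophenyl in place of 2-chlorophenyl on an aromatic nitrogen. Among the compounds with values here, no measured step moves a chloro between positions, so the only bearing comes from the hydrogen-to-chloro step in compound 3 and the hydrogen-to-fluoro step in compound 2: halogen at one place helped, halogen at another did not. The benefit of the 2-chlorophenyl is therefore not assumed to carry over fully to the 4-chlorophenyl; in this assay a somewhat higher number than compound 3 is expected, of the order a 2.7-fold higher number from compound 3 to compound 4 (0.42 log units; beyond the scatter). The estimate for compound 4 is 8000 nM, with a range from 2500 nM to 25000 nM.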

Compound 4, half-maximal inhibitory concentration: 2160 nM
Compound 4: the middle estimate sits 3.7-fold (0.57 log units) above what was measured, outside the stated range (below it).
By their numbers in this assay, from the lowest: compounds 4 and 3 (each within the scatter of the next); then compound 1. At a limit, above all of these: compound 2.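

In this assay, swapping the 2-chlorophenyl for the 4-chlorophenyl gives a 1.4-fold lower number from compound 3 to compound 4 (0.14 log units; within the scatter), so these two chloro placings cannot be ordered, and the gain seen with the 2-chlorophenyl is not confined to that one placing. The 4-chlorophenyl also stands clear of the unsubstituted phenyl, with an 8.0-fold lower number from compound 1 to compound 4 (0.90 log units; beyond the scatter), which means that both chloro compounds now lie beyond the scatter from the parent phenyl in the same direction. The step from the 3-fluorophenyl can be read only as a floor, an at least 9.2-fold lower number from compound 2 to compound 4 (0.96 log units; beyond the scatter), and the value it starts from is a limit of the assay and not a number: the limit of > 20000 nM in this assay, at which 1 of the 4 values shown sits.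

Still open, from the compounds shown here alone, is whether a 3-chlorophenyl would sit with compound 3 and compound 4 or with compound 2, since fluoro and chloro are not compared here at one shared placing on the phenyl. Also open, going by these compounds, is whether the gain depends on a halogen at all or would persist with a methyl, a methoxy, an amine or a carboxylic acid on the same phenyl.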